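Moving the ring nitrogen of the hydrazone pyridine

The source may report more compounds than this note shows. Statements on the series, on what has been measured and on what is new or still open speak of the compounds shown alone.

Of the compounds shown here, two with a shared core have been measured in an ADME assay on HT-29 cells (Homo sapiens) for inhibition, read by MTT assay, with a stated time of 72 h; a higher number here means a weaker inhibitor, a lower number a stronger inhibitor. Compound 1 `CN(C)C/C=C/C(=O)Nc1cccc(Nc2nc(N/N=C/c3ccc(F)cc3)ncc2Cl)c1` carries a fluorophenyl hydrazone and gives 3300 nM. Compound 2 `C/C(=N\Nc1ncc(Cl)c(Nc2cccc(NC(=O)/C=C/CN(C)C)c2)n1)c1ccccn1` carries a pyridin-2-yl ketone hydrazone instead and gives 120 nM. Among the measured compounds shown here, the step of a 28-fold lower number from compound 1 to compound 2 (1.44 log units; beyond the scatter) is the only measured step, and it places compound 2 at the lowest number of the two.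

Compound 3 `C/C(=N\Nc1ncc(Cl)c(Nc2cccc(NC(=O)/C=C/CN(C)C)c2)n1)c1cccnc1` has the same atoms as compound 2, joined differently: pyridin-3-yl in place of pyridin-2-yl on a carbon with a double bond to nitrogen. For the measured compounds named here, no measured step exchanges one pyridyl for another, so the only bearing comes from the step from compound 1 to compound 2, which shows that the aryl group on this hydrazone carbon can move the number a great deal. Because a 28-fold lower number from compound 1 to compound 2 (1.44 log units; beyond the scatter) was large and favoured the pyridin-2-yl group, the shift to pyridin-3-yl is expected to give a weaker inhibitor, though by a smaller margin. The estimate for compound 3 in this assay is 400 nM, within a range from 120 nM to 1500 nM. This corresponds to an expected step of a 3.3-fold higher number from compound 2 to compound 3 (0.52 log units; beyond the scatter).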

Compound 3, half-maximal inhibitory concentration: 9660 nM
The estimate for compound 3 lay 24-fold (1.38 log units) below the measured number, and the stated range ends below it.
By their numbers in this assay, from the lowest: compound 2; then compound 1; then compound 3.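

In this assay, the placement of the ring nitrogen is enough on its own to produce a large change at this position: with the atoms otherwise the same, pyridin-3-yl in place of pyridin-2-yl on a carbon with a double bond to nitrogen gives an 81-fold higher number from compound 2 to compound 3 (1.91 log units; beyond the scatter). The earlier gain therefore does not extend to pyridine rings in general, since the other pyridine compound reads weaker than the fluorophenyl hydrazone, with a 2.9-fold higher number from compound 1 to compound 3 (0.47 log units; beyond the scatter), so only pyridin-2-yl among the two pyridyl groups improves on that compound. Nothing available here accounts for why the two pyridyl groups differ so sharply.

Compound 1 differs from compound 2 and compound 3 both in its ring and in having a hydrogen rather than a methyl on the hydrazone carbon, so the compounds shown cannot separate the contribution of the methyl from that of the ring. A plain phenyl group on the methyl-bearing carbon, or a pyridin-2-yl group on a carbon bearing hydrogen, would be needed to tell those two contributions apart.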